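Compound 3 to compound 4: bromo for methyl

The source may hold more compounds than are shown below. What is called first, only, known or untested is meant among the compounds shown, and "the series" means these compounds.

In a functional assay on MGC-803 cells (Homo sapiens) for cytotoxicity, read by MTT assay, with a stated time of 48 h (on this read-out lower numbers stand for stronger inhibition and higher numbers for weaker inhibition), compound 1 (`CC1=NN(C(=O)CN2CCCCC2[N+](=O)[O-])C(c2ccccc2O)C1`) gives 28300 nM while compound 2 (`CCC1CCCCN1CC(=O)N1N=C(c2cc3ccccc3oc2=O)CC1c1ccccc1`) gives 8710 nM and compound 3 (`CC1CCN(CC(=O)N2N=C(c3cc4ccccc4oc3=O)CC2c2ccccc2)CC1`) gives 3010 nM as the lowest of the three numbers. Compound 4 (`O=C(CN1CCC(Br)CC1)N1N=C(c2cc3ccccc3oc2=O)CC1c1ccccc1`) is still unmeasured and differs from compound 3 by bromo in place of methyl on a saturated ring carbon. Within the data shown here, one measured step bears on this change: 4-methylpiperidin-1-yl in place of 2-ethylpiperidin-1-yl gave a 2.9-fold lower number from compound 2 to compound 3 (0.46 log units; beyond the scatter) (modest, though beyond the scatter). Among the measured compounds shown here, that step changes the group on the same ring, but no measured step replaces methyl with bromo, so the data give no direction for this exchange. In this assay no step beyond the scatter is therefore expected. The estimated change is a 1.0-fold lower number from compound 3 to compound 4 (0.00 log units; within the scatter) (within the scatter). The range is set to allow a step of about the measured size in either direction. For compound 4 the expected value is 3000 nM with an estimated range from 1050 nM to 8600 nM as its limits.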

Compound 4, half-maximal inhibitory concentration: 7010 nM
Estimate against measurement, compound 4: 2.3-fold (0.37 log units) below, and the stated range covers the measured number.
By their numbers in this assay, from the lowest: compound 3; then compounds 4 and 2 (each within the scatter of the next); then compound 1.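

In this assay the saturated ring carbon three ring bonds from the ring nitrogen does respond to its substituent: bromo in place of methyl gives a 2.3-fold higher number from compound 3 to compound 4 (0.37 log units; beyond the scatter) as a modest step, and 4-methylpiperidin-1-yl keeps the lower number of this pair. Against the 2-ethylpiperidin-1-yl group, 4-bromopiperidin-1-yl gives a 1.2-fold lower number from compound 2 to compound 4 (0.09 log units; within the scatter) and so does not carry over the advantage that 4-methylpiperidin-1-yl showed over that group. Nothing measured here accounts for the difference between bromo and methyl at this place.

The compounds shown carry only methyl and bromo on this ring carbon, so the outcome with a hydroxyl group, an amine or a carboxylic acid there remains open. Going by these compounds, whether bromo for methyl reads the same way on another carbon of the ring also remains open.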